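Ethyl amide step on the thiophene analogue

The source may hold more compounds than are shown below. What is called first, only, known or untested is meant among the compounds shown, and "the series" means these compounds.

Compound 1 `CC1=C(C(N)=O)C(c2ccoc2)NC(=O)N1` is the reference point of this small set. In an assay on membranes from HEK293 cells for displacement of a labelled ligand from adenosine receptor A2b (Homo sapiens), read by scintillation counting, with a stated time of 30 min, tested at 1 uM (a higher number here means more inhibition at the concentration tested (going by the name of the read-out), a lower number less inhibition), compound 1 gives 6%. Compound 2 `CCNC(=O)C1=C(C)NC(=O)NC1c1ccoc1` carries the change (ethyl in place of hydrogen on an amide-type nitrogen), and in this assay compound 2 gives 2%; the step of a number 4 percentage points lower from compound 1 to compound 2 (within the scatter) is within the usual scatter, so the two numbers are read as indistinguishable. Compound 3 `CC1=C(C(N)=O)C(c2ccsc2)NC(=O)N1` differs from compound 1 by thiophen-3-yl in place of furan-3-yl on a saturated ring carbon, and in this assay compound 3 gives 1%; the step of a number 5 percentage points lower from compound 1 to compound 3 (within the scatter) is again within the scatter. All three measured values sit at a level where essentially no inhibition is seen at the concentration tested.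

Compound 4 `CCNC(=O)C1=C(C)NC(=O)NC1c1ccsc1` has not yet been measured in this assay. It differs from compound 3 by ethyl in place of hydrogen on an amide-type nitrogen, the same change that was made from compound 1 to compound 2, and among the compounds shown it occurs twice in all. The place of the change is the same in both pairs, an amide-type nitrogen whose other neighbour is a carbonyl carbon, so this is the same change on a core that differs by thiophen-3-yl in place of furan-3-yl on a saturated ring carbon.

Among the compounds with values here, the step of a number 1 percentage points lower from compound 3 to compound 4 (within the scatter) is expected to be of the same small size as a number 4 percentage points lower from compound 1 to compound 2 (within the scatter), that is, within the scatter, because the only measured instance of this change, a number 4 percentage points lower from compound 1 to compound 2 (within the scatter), moved the number by little. On that basis compound 4 is estimated at 0% in this assay, with an expected range from -8% to 8%.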

Compound 4, a percentage reported as inhibition, at one concentration (the size of the read-out at that concentration, not a potency): 1%
For compound 4 the middle estimate is 1 percentage points below the measured one, and the stated range covers the measured number.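

In this assay, ethyl in place of hydrogen on the amide-type nitrogen gives no change at the digits printed from compound 3 to compound 4 (within the scatter), and this step agrees with the one seen on the core of compound 1: the same change on two cores in this assay, a number 4 percentage points lower (within the scatter) from compound 1 to compound 2 and no change at the digits printed (within the scatter) from compound 3 to compound 4, 4 percentage points apart, within the scatter of two such steps. Thiophen-3-yl in place of furan-3-yl on a saturated ring carbon reads the same way on the ethyl amides, with a number 1 percentage points lower from compound 2 to compound 4 (within the scatter), and this also agrees with the earlier step: the same change on two cores in this assay, a number 5 percentage points lower (within the scatter) from compound 1 to compound 3 and a number 1 percentage points lower (within the scatter) from compound 2 to compound 4, 4 percentage points apart, within the scatter of two such steps. Within the data shown here, the agreement shows only that neither change gives a readable step on these cores; with all four compounds at a level of essentially no inhibition at the concentration tested, it does not show that a step of real size would carry unchanged from one core to the other.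

The compounds shown leave open whether any substituent on the amide-type nitrogen other than ethyl, such as a longer chain or a benzyl group, gives a number beyond the scatter in this assay. Also open, from the compounds shown here alone, is whether a phenyl ring on the saturated ring carbon, or a carboxylic acid in place of the carbamoyl group, moves the number away from this low level.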